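Furan-2-yl in place of pyridin-2-yl on the shared core

A few compounds are considered here, and "the series" means these few. Any claim that something is new, unique, unknown or untested is made for them only; others in the source may bear on it.

Of the compounds shown here, three have been measured in a functional assay on T47D cells (Homo sapiens) for cytotoxicity, read by CCK-8 assay and cell counting, with a stated time of 2 days; a lower number here means a stronger inhibitor, a higher number a weaker inhibitor. Compound 1 `Oc1ccc(-c2cc(-c3ccc(Cl)cc3)nc(-c3cccs3)c2)cc1` gives 6450 nM, compound 2 `Oc1ccc(-c2cc(-c3ccc(Cl)cc3)nc(-c3ccsc3)c2)cc1` gives 5490 nM, and compound 3 `Oc1ccc(-c2cc(-c3ccc(Cl)cc3)nc(-c3ccccn3)c2)cc1` gives 25900 nM. Compound 3 thus shows the highest number of the three: its nearest neighbour is compound 1, its furthest compound 2, and both gaps lie beyond the scatter, so compound 3 is the weakest inhibitor of the set so far. The two thiophene analogues differ only by a 1.2-fold lower number from compound 1 to compound 2 (0.07 log units; within the scatter), which is within the scatter.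

Compound 4 `Oc1ccc(-c2cc(-c3ccc(Cl)cc3)nc(-c3ccco3)c2)cc1` is not yet measured. It differs from compound 3 by furan-2-yl in place of pyridin-2-yl on an aromatic carbon. Among the compounds with values here, the steps that bear on this change run the other way: a 4.0-fold higher number from compound 1 to compound 3 (0.60 log units; beyond the scatter) and a 4.7-fold higher number from compound 2 to compound 3 (0.67 log units; beyond the scatter), both modest and beyond the scatter. Both replace a five-membered sulfur heteroaryl with pyridin-2-yl and both raise the number. Compound 4 reintroduces a five-membered heteroaryl, furan-2-yl, so a decrease of comparable size in this assay is expected, though no furan has been measured here and the match to the thiophenes is only partial.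

Compound 4 is therefore estimated at 7500 nM, with a range of 3500 nM to 16000 nM, corresponding to an expected step of a 3.5-fold lower number from compound 3 to compound 4 (0.54 log units; beyond the scatter).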

Compound 4, half-maximal inhibitory concentration: 6260 nM
Beside the measured number, compound 4's estimate is 1.2-fold (0.08 log units) above it; the range from low to high includes it.
By their numbers in this assay, from the lowest: compounds 2, 4 and 1 (each within the scatter of the next); then compound 3.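

Replacing pyridin-2-yl with furan-2-yl gives a 4.1-fold lower number from compound 3 to compound 4 (0.62 log units; beyond the scatter) in this assay, so the loss seen with pyridin-2-yl at this place is recovered with a different five-membered ring and does not depend on a thiophene. Compared with the thiophenes, the furan gives a 1.1-fold higher number from compound 2 to compound 4 (0.06 log units; within the scatter) and a 1.0-fold lower number from compound 1 to compound 4 (0.01 log units; within the scatter), which leaves compounds 1, 2 and 4 unresolved from one another: across these four compounds, the oxygen and sulfur rings and both thiophene attachments read alike, compound 3 alone stands apart as the weakest, and no compound goes against this pattern. No accompanying measurement is available to account for the gap between compound 3 and the other three.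

The compounds shown leave open whether the higher number belongs to pyridin-2-yl alone or to six-membered aromatic rings more widely, a question that phenyl, pyridin-3-yl or pyridin-4-yl at this place would address. Also open, from the compounds shown here alone, is how a saturated amine such as morpholine would read here, and how far the result holds with changes to the 4-chlorophenyl and 4-hydroxyphenyl groups, which are the same in all four compounds.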